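This account rests on a few compounds, and the source may have more. Where it says the series, first, only, none or still open, it means among the compounds named here.

Measured in a functional assay on HL-60 cells (Homo sapiens) for cytotoxicity, read by WST assay, with a stated time of 48 h; on this read-out higher numbers stand for weaker inhibition and lower numbers for stronger inhibition:
compound 1 `COc1cc(C(c2ccc(O)c(OC)c2)[C@H](C)[C@H](C)CO)ccc1O`: > 100000 nM (a limit)
compound 2 `COc1cc(C(c2ccc(O)c(OC)c2)[C@@H](C)[C@@H](C)CF)ccc1O`: 38000 nM
compound 3 `COc1cc(C(c2ccc(O)c(OC)c2)[C@@H](C)[C@H](C)CF)ccc1O`: 32000 nM

Within the data shown here, compound 3 at 32000 nM and compound 2 at 38000 nM are the only true numbers, and they lie within the scatter of each other. Compound 4 `COc1cc(C(c2ccc(O)c(OC)c2)[C@H](C)[C@@H](C)CO)ccc1O` departs from compound 3 by 2-(hydroxymethyl)-1-methylpropyl in place of 2-(fluoromethyl)-1-methylpropyl on a saturated chain carbon bound to two aromatic carbons.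

The opposite change was measured in two steps, an at least 2.6-fold lower number from compound 1 to compound 2 (0.42 log units; beyond the scatter) and an at least 3.1-fold lower number from compound 1 to compound 3 (0.49 log units; beyond the scatter). Both rest on (the limit of > 100000 nM in this assay, at which 1 of the 3 values shown sits). Among the measured compounds shown here, the one configuration step, a 1.2-fold lower number from compound 2 to compound 3 (0.07 log units; within the scatter), stayed within the scatter. Going by an at least 3.1-fold lower number from compound 1 to compound 3 (0.49 log units; beyond the scatter), a higher number is expected in this assay, possibly only a limit. The expected step is a 3.8-fold higher number from compound 3 to compound 4 (0.57 log units; beyond the scatter). For compound 4 the estimated value is 120000 nM, with an expected range of 50000 nM to 300000 nM.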

Compound 4, half-maximal inhibitory concentration: > 100000 nM
Compound 4: a limit, no number; the forecaster's own chance of this, stated with the estimate: 70%; the middle value lies beyond the limit too.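

In this assay compound 4 gives > 100000 nM, a limit and not a number. With 2-(hydroxymethyl)-1-methylpropyl in place of 2-(fluoromethyl)-1-methylpropyl, the steps are an at least 3.1-fold higher number from compound 3 to compound 4 (0.49 log units; beyond the scatter) and an at least 2.6-fold higher number from compound 2 to compound 4 (0.42 log units; beyond the scatter), so the loss now holds for both hydroxymethyl configurations shown, not only that of compound 1. The step between compound 1 and compound 4 cannot be read, and any effect of configuration among the hydroxymethyl compounds stays hidden: the limit of > 100000 nM in this assay, at which 2 of the 4 values shown sit.

Open, going by these compounds, is how far the hydroxymethyl compounds lie past the limit. Also open, on these data alone, is whether an amine or a chloromethyl end on this chain would differ from the fluoromethyl compounds.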